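Dithiocarbamate-linked benzamides: amine ring variation

The source may hold more compounds than are shown below. What is called first, only, known or untested is meant among the compounds shown, and "the series" means these compounds.

In a functional assay on A-375 cells (Homo sapiens) for antiproliferative activity, read by CCK-8 assay, with a stated time of 72 h, tested at 8 uM (a lower number here means a weaker effect, a higher number a stronger effect of the compound at the concentration tested), compound 1 `Nc1ccccc1NC(=O)c1ccc(CSC(=S)N2CCN(c3ccc(F)cc3)CC2)cc1` gives 76.3% and compound 2 `CC1CCCCN1C(=S)SCc1ccc(C(=O)Nc2ccccc2N)cc1` gives 85.2%. Compound 2 stands highest of the two numbers, but its nearest neighbour, compound 1, lies within the scatter, so the two cannot be ordered on these data. Among the measured compounds shown here, no step between measured compounds is available for the part of the molecule varied here, so the size of any effect of changing the amine on the thiocarbonyl carbon is unknown from the series itself.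

Compound 3 `Nc1ccccc1NC(=O)c1ccc(CSC(=S)N2CCCC2)cc1` is the next entry to be measured in this assay. It differs from compound 2 in one place: pyrrolidin-1-yl in place of 2-methylpiperidin-1-yl on a thiocarbonyl carbon. Both amines are saturated rings without donors or acceptors, and the rest of the shared core is unchanged.

Given that compound 1 gives 76.3% and compound 2 gives 85.2% in this assay, compound 3 is expected to fall in the same region, with a step of a number 7.2 percentage points lower from compound 2 to compound 3 (within the scatter) of no more than the scatter. The estimated value for compound 3 is 78%, within 60% to 92%.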

Compound 3, a percentage reported as inhibition, at one concentration (the size of the read-out at that concentration, not a potency): 89.5%
The estimate for compound 3 lay 11.5 percentage points below the measured number; measured number inside the range.
By their numbers in this assay, from the lowest: compounds 1, 2 and 3 (each within the scatter of the next, the first and the last beyond it).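

Working notes: the series now has its first readable step at this position. In this assay, pyrrolidin-1-yl in place of 2-methylpiperidin-1-yl on a thiocarbonyl carbon gives a number 4.3 percentage points higher from compound 2 to compound 3 (within the scatter), so the exchange of these two saturated rings, which also removes the methyl group, leaves the read-out within what repeated measurements would scatter over at this concentration. Among the compounds shown here, the three values taken together add one further point: compound 1 gives 76.3% and compound 3 gives 89.5%, a pair that lies beyond the scatter, which is the first sign that the amine on the thiocarbonyl carbon can matter in this assay, though each of the two gaps to compound 2 stays within the scatter.

No measurement in hand bears on the reason for these numbers. Open, from the compounds shown here alone, is whether morpholin-4-yl or an open-chain amine such as diethylamino on the thiocarbonyl carbon would stay in this region, and whether these read-outs at a single concentration carry over to potencies.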